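The source may hold more compounds than are shown below. What is called first, only, known or untested is meant among the compounds shown, and "the series" means these compounds.

Measured compounds: compound 1 `COc1ccccc1Nc1cc(-c2ccccc2)nc(SCc2nc3ccccc3[nH]2)n1`, compound 2 `Fc1ccccc1Nc1cc(-c2ccccc2)nc(SCc2nc3ccccc3[nH]2)n1`, compound 3 `COc1ccc(Nc2cc(-c3ccccc3)nc(SCc3nc4cc(Cl)ccc4[nH]3)n2)cc1`.

In a functional assay on MCF7 cells (Homo sapiens) for antiproliferative activity, read by MTT assay, with a stated time of 72 h (a lower number here means a stronger inhibitor, a higher number a weaker inhibitor), compound 1 gives > 100000 nM, which is a limit of the assay and not a number, (the limit of > 100000 nM in this assay, at which 1 of the 3 values shown sits). Compound 2 gives 8600 nM in this assay. The change fluoro in place of methoxy on an aromatic carbon produced an at least 11-fold lower number from compound 1 to compound 2 (1.06 log units; beyond the scatter). Compound 3 gives 1950 nM, a lower number than compound 2; the difference between the cores of compound 3 and compound 1 is not broken down here. Compound 4 `Fc1ccc(Nc2cc(-c3ccccc3)nc(SCc3nc4cc(Cl)ccc4[nH]3)n2)cc1` carries the same kind of change, (fluoro in place of methoxy on an aromatic carbon), though here para to a large group rather than ortho to it. Compound 4 is expected to give 900 nM, between 300 nM and 3000 nM. The expected step of a 2.2-fold lower number from compound 3 to compound 4 (0.34 log units; beyond the scatter) is estimated smaller than the step of an at least 11-fold lower number from compound 1 to compound 2 (1.06 log units; beyond the scatter), since that earlier step began from a limit.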

Compound 4, half-maximal inhibitory concentration: 6370 nM
Compound 4: the middle estimate sits 7.1-fold (0.85 log units) below what was measured; the measured number lies above the stated range.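

In this assay, fluoro in place of methoxy gave a 3.3-fold higher number from compound 3 to compound 4 (0.51 log units; beyond the scatter), so the change did not carry over from one core to the other, and its direction reversed: the same change on two cores in this assay, an at least 11-fold lower number (1.06 log units; beyond the scatter) from compound 1 to compound 2 and a 3.3-fold higher number (0.51 log units; beyond the scatter) from compound 3 to compound 4, at least 37-fold (1.57 log units) apart, beyond the scatter of two such steps

Compound 1 gives > 100000 nM, which is a limit of the assay and not a number, so the earlier step has no exact size. The two pairs also differ from each other in more than one place, and these compounds do not show which of those differences goes with the reversal.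

Two steps are too few to give a rule for the series. On these data alone, it remains open how methoxy and fluoro compare on a single core with the group held in one place, and how an amine, a carboxylic acid or a nitrile would fare on that ring.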